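4-Methylpiperazin-1-yl in place of piperidin-1-yl: working notes

The source may hold more compounds than are shown below. What is called first, only, known or untested is meant among the compounds shown, and "the series" means these compounds.

In a functional assay on A549 cells (Homo sapiens) for antiproliferative activity, read by MTT assay, with a stated time of 72 h (a lower number here means a stronger inhibitor, a higher number a weaker inhibitor), compound 2 `O=C(N/N=C/c1cccn1CCCN1CCCCC1)Nc1ccc(Oc2ccnc3[nH]ccc23)cc1` gives 1560 nM and compound 1 `CN1CCN(CCCn2cccc2/C=N/NC(=O)Nc2ccc(Oc3ccnc4[nH]ccc34)c(F)c2)CC1` gives 2200 nM, two values within the scatter of each other. Compound 3 `CN1CCN(CCCn2cccc2/C=N/NC(=O)Nc2ccc(Oc3ccnc4[nH]ccc34)cc2)CC1` remains unmeasured. Its change from compound 2 is 4-methylpiperazin-1-yl in place of piperidin-1-yl on a saturated chain carbon, three bonds along the chain from an aromatic nitrogen, with 4-methylpiperazin-1-yl in place of piperidin-1-yl on a saturated chain carbon. For the measured compounds named here, no measured pair isolates this change, so no step beyond the scatter is expected in this assay, in either direction. The estimated 1.2-fold higher number from compound 2 to compound 3 (0.06 log units; within the scatter) stays within the scatter. For compound 3 the expected value is 1800 nM, with an estimated range of 700 nM to 4500 nM here.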

Compound 3, half-maximal inhibitory concentration: 1640 nM
Compound 3: the middle estimate sits 1.1-fold (0.04 log units) above what was measured; the measured number falls inside the stated range.
By their numbers in this assay, from the lowest: compounds 2, 3 and 1 (each within the scatter of the next).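

In this assay there is a 1.1-fold higher number from compound 2 to compound 3 (0.02 log units; within the scatter) for 4-methylpiperazin-1-yl in place of piperidin-1-yl on a saturated chain carbon, so this swap at this position leaves the number within the scatter. Hydrogen in place of fluoro on an aromatic carbon now reads as a single change too, with a 1.3-fold lower number from compound 1 to compound 3 (0.13 log units; within the scatter) and again no step beyond the scatter. No evidence here bears on the reason for either result.

As far as these compounds go, whether morpholin-4-yl or a primary amine in place of these rings, or a longer chain, would give a step beyond the scatter stays open, as does the effect of chloro or methoxy in place of fluoro.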